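The source may report more compounds than this note shows. Statements on the series, on what has been measured and on what is new or still open speak of the compounds shown alone.

Measured so far in a functional assay on PC-3 cells (Homo sapiens) for inhibition; on this read-out lower numbers stand for stronger inhibition and higher numbers for weaker inhibition:
compound 1 `CC(O)(CS(=O)(=O)c1ccc(F)cc1)c1cn(-c2ccc(C#N)c(C(F)(F)F)c2)nn1` — > 300000 nM
compound 2 `CC(O)(CS(=O)(=O)c1ccc(F)cc1)c1cn(-c2ccc([N+](=O)[O-])c(C(F)(F)F)c2)nn1` — > 300000 nM
compound 3 `CCOC(=O)c1ccc(-n2cc(C(C)(O)CS(=O)(=O)c3ccc(F)cc3)nn2)cc1` — > 300000 nM

Where compound 1 stands: its value in this assay is a limit of the assay, not a number. Compound 2 likewise gives only a limit. Compound 3 likewise gives only a limit. All three values sit at the limit of > 300000 nM in this assay, at which 3 of the 3 values shown sit. Among the compounds with values here, the single one-place step, a step that the two limits leave unreadable from compound 1 to compound 2, therefore has no readable size, and no ordering among compound 1, compound 2 and compound 3 can be drawn from these values.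

Compound 4 `CC(O)(CS(=O)(=O)c1ccccc1)c1cn(-c2ccc(C#N)c(C(F)(F)F)c2)nn1` differs from compound 1 by hydrogen in place of fluoro on an aromatic carbon. Within the data shown here, none of the measured compounds probes this fluoro-to-hydrogen exchange on the sulfonyl-bearing ring, and the only measured step gives no size at all, so nothing supports expecting a step in this assay in either direction beyond the scatter. Compound 4 is expected to stay at the limit as well, and the step that the limit leaves unreadable from compound 1 to compound 4 is expected to be unreadable. Compound 4 is estimated at 500000 nM, with a range from 100000 nM to 3000000 nM.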

Compound 4, half-maximal inhibitory concentration: 114000 nM
Compound 4: the middle estimate sits 4.4-fold (0.64 log units) above what was measured, within the range that was stated.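

Hydrogen in place of fluoro on the aromatic carbon para to a large group gives the first readable step in this series: in this assay, it is an at least 2.6-fold lower number from compound 1 to compound 4 (0.42 log units; beyond the scatter). Compound 4, at 114000 nM, is the only compound shown with a number rather than a limit, so the 4-fluorophenyl to phenyl change is a position where the read-out responds, whereas the exchange of nitrile for nitro gave no readable size. The other three compounds give no measured number: the limit of > 300000 nM in this assay, at which 3 of the 4 values shown sit.

On these data alone, the full size of the step stays open, since the value for compound 1 is a limit, and it is unclear whether the same exchange would bring compound 2 or compound 3 to a number. Also open, as far as these compounds go, is how chloro or methoxy at this position would compare with hydrogen on the core of compound 4.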